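The source may report more compounds than this note shows. Statements on the series, on what has been measured and on what is new or still open speak of the compounds shown alone.

Compound 2, `CC(C)c1ccc(CNC(=O)C(C)c2ccc(NS(C)(=O)=O)c(F)c2)cc1`, holds the lower of the two numbers measured in an assay on CHO cells for displacement of a labelled ligand from transient receptor potential cation channel subfamily V member 1 (Rattus norvegicus) (a lower number here means a stronger inhibitor, a higher number a weaker inhibitor), where compound 2 gives 127 nM. Going by the values given here, its nearest measured neighbour is compound 1, `CC(C(=O)NCc1ccc(Br)cc1)c1ccc(NS(C)(=O)=O)c(F)c1`, which in this assay gives 412 nM; the single measured step runs a 3.2-fold lower number from compound 1 to compound 2 (0.51 log units; beyond the scatter). Compound 3, `CC(C(=O)NCc1ccc(C2C=CCC2)cc1)c1ccc(NS(C)(=O)=O)c(F)c1`, differs from compound 2 in one place: cyclopent-2-en-1-yl in place of isopropyl on an aromatic carbon. Among the compounds with values here, only one measured step bears on this change, and it acts at the same aromatic carbon: a 3.2-fold lower number from compound 1 to compound 2 (0.51 log units; beyond the scatter). Within the data shown here, the present change again replaces the group at that carbon with one of more heavy atoms, so a further lowering in this assay is plausible, but the one precedent is modest, and the entering group brings a five-membered non-aromatic ring and a double bond for which no measured comparison exists. Compound 3 is therefore expected to show a step of about a 1.4-fold lower number from compound 2 to compound 3 (0.15 log units; within the scatter), a small lowering that could as well fall within the scatter. On this basis compound 3 is estimated at 90 nM, with a range from 35 nM to 250 nM.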

Compound 3, inhibition constant: 162 nM
The estimate for compound 3 lay 1.8-fold (0.26 log units) below the measured number; the range from low to high includes it.
By their numbers in this assay, from the lowest: compounds 2 and 3 (each within the scatter of the next); then compound 1.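

In this assay, the step of a 1.3-fold higher number from compound 2 to compound 3 (0.11 log units; within the scatter) shows that the aromatic carbon para to a large group takes cyclopent-2-en-1-yl, with its five-membered non-aromatic ring and its double bond, without a difference from isopropyl that can be told from the scatter. The carbon groups now compare in the same way with bromo, as the earlier step of a 3.2-fold lower number from compound 1 to compound 2 (0.51 log units; beyond the scatter) is joined by a second one beyond the scatter, a 2.5-fold lower number from compound 1 to compound 3 (0.41 log units; beyond the scatter) and none of the three compounds goes against this, although the new step is modest and the pattern rests on these compounds alone. Nothing shown gives a reason for these results.

The compounds shown leave open how the saturated cyclopentyl would compare with cyclopent-2-en-1-yl, and so whether the double bond plays any part at this carbon. They also leave open how this carbon would respond to a phenyl ring, an amine, a carboxylic acid or a longer alkyl chain, and whether the same order would hold with a different group elsewhere on the core.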